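Amide changes and cytotoxicity limits: toward compound 4

The source may hold more compounds than are shown below. What is called first, only, known or untested is meant among the compounds shown, and "the series" means these compounds.

- compound 1 `COc1ccc(C(=O)/C=C/c2ccc(C(=O)N3CCCC3)cc2)c(O)c1` in an ADME assay on SH-SY5Y cells (Homo sapiens) for cytotoxicity, read by MTT assay, with a stated time of 48 h; a lower number here means a stronger inhibitor, a higher number a weaker inhibitor: > 100000 nM, a limit
- compound 2 `CCCNC(=O)c1ccc(/C=C/C(=O)c2ccc(OC)cc2O)cc1` in this assay: > 100000 nM, a limit
- compound 3 `CCCCCCCCCCCCNC(=O)c1ccc(/C=C/C(=O)c2ccc(OC)cc2O)cc1` in this assay: > 100000 nM, a limit

Compound 2 has only a limit and no number. The whole measured set stands at the limit of > 100000 nM in this assay, at which 3 of the 3 values shown sit, so the compounds cannot be ranked.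

Compound 4 `COc1ccc(C(=O)/C=C/c2ccc(C(=O)Nc3ccccc3O)cc2)c(O)c1` carries 2-hydroxyphenyl in place of propyl on an amide-type nitrogen. Within the data shown here, two measured steps bear on this change: a step that the two limits leave unreadable from compound 1 to compound 2 and a step that the two limits leave unreadable from compound 2 to compound 3. Among the measured compounds shown here, neither has a readable size, and no measured compound carries 2-hydroxyphenyl, so their guidance is weak.

With compound 3 still giving a limit after a step that the two limits leave unreadable from compound 2 to compound 3, no step beyond the scatter is expected in this assay. A lower number remains the only direction that could be read. The expected step is a number no higher from compound 2 to compound 4 (the limit leaves the size open). For compound 4 the estimated value is 100000 nM, with an expected range from 30000 nM to 200000 nM.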

Compound 4, half-maximal inhibitory concentration: > 100000 nM
Compound 4: a limit, no number; the forecaster's own chance of this, stated with the estimate: 70%; the middle value sits exactly at the limit.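

No new step can be read from compound 1 or compound 2 to compound 4, as all the values are limits: the limit of > 100000 nM in this assay, at which 4 of the 4 values shown sit.

The compounds shown leave open whether any amide in this series reaches a numerical value in this assay, and how amide changes would shift it.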